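A few compounds are considered here, and "the series" means these few. Any claim that something is new, unique, unknown or untested is made for them only; others in the source may bear on it.

Compound 3 `COC(=O)C#CC(O/C=C/C(=O)OC)C(C)(C)C` carries a tert-butyl group on the saturated chain carbon bound to an oxygen on an unsaturated carbon and a triple-bonded carbon. For the measured compounds named here, in a functional assay on HBL-100 cells (Homo sapiens) for antiproliferative activity, read by sulforhodamine B assay, with a stated time of 48 h (on this read-out higher numbers stand for weaker inhibition of growth and lower numbers for stronger inhibition of growth), compound 3 gives 1800 nM, the highest of the three numbers measured so far. Compound 1 `COC(=O)C#CC(CC(C)C)O/C=C/C(=O)OC` gives 330 nM in this assay, and compound 2 `CCC(C)C(C#CC(=O)OC)O/C=C/C(=O)OC` gives 340 nM; the step between these two, a 1.0-fold higher number from compound 1 to compound 2 (0.01 log units; within the scatter), shows no difference beyond the scatter. The two steps that reach compound 3 are a 5.5-fold higher number from compound 1 to compound 3 (0.74 log units; beyond the scatter) and a 5.3-fold higher number from compound 2 to compound 3 (0.72 log units; beyond the scatter), both modest and beyond the scatter.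

Going by the values given here, compound 4 `COC(=O)C#CC(C)O/C=C/C(=O)OC` is not yet measured. methyl in place of tert-butyl on a saturated chain carbon bound to an oxygen on an unsaturated carbon and a triple-bonded carbon The measured steps that bear on this position are a 5.5-fold higher number from compound 1 to compound 3 (0.74 log units; beyond the scatter) and a 5.3-fold higher number from compound 2 to compound 3 (0.72 log units; beyond the scatter); each exchanges one four-carbon branched group for another, and no measured compound carries a one-carbon group here. A lower number than compound 3 is expected in this assay, since moving away from tert-butyl coincided with lower numbers in both steps, but the size of the expected step is uncertain, so a wide range is given. The expected step is a 3.6-fold lower number from compound 3 to compound 4 (0.56 log units; beyond the scatter). For compound 4 the estimate in this assay is 500 nM, with a range from 150 nM to 1800 nM.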

Compound 4, concentration for 50% growth inhibition: 300 nM
Compound 4: middle estimate off by 1.7-fold (0.22 log units), on the high side; the range from low to high includes it.
By their numbers in this assay, from the lowest: compounds 4, 1 and 2 (each within the scatter of the next); then compound 3.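

In this assay, for the compounds shown here, the change to methyl on the saturated chain carbon bound to an oxygen on an unsaturated carbon and a triple-bonded carbon gives a 6.0-fold lower number from compound 3 to compound 4 (0.78 log units; beyond the scatter) and puts a one-carbon group at this position for the first time. That one-carbon group does not separate from the two branched groups, with a 1.1-fold lower number from compound 2 to compound 4 (0.05 log units; within the scatter) and a 1.1-fold lower number from compound 1 to compound 4 (0.04 log units; within the scatter) both within the scatter. Among these four compounds, tert-butyl in compound 3 is therefore the only group set apart, and methyl, isobutyl and sec-butyl show no trend with the number of carbons in the group. Nothing available here explains why tert-butyl alone stands apart.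

Open, on these data alone, is how a longer straight chain such as n-hexyl, a phenyl ring, or a group carrying an amine or a hydroxyl would read at this position. Also open, as far as these compounds go, is whether the level shared by compounds 1, 2 and 4 would hold if the methyl esters of the shared core gave way to a carboxylic acid or an amide.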